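Ethoxycarbonyl in place of carboxy on the shared core

The source may report more compounds than this note shows. Statements on the series, on what has been measured and on what is new or still open speak of the compounds shown alone.

Measured so far in a functional assay on MCF7 cells (Homo sapiens) for cytotoxicity, read by MTT assay, with a stated time of 72 h; on this read-out higher numbers stand for weaker inhibition and lower numbers for stronger inhibition:

compound 1, `Cc1oc2ncnc(Nc3cccc(Br)c3)c2c1C(=O)O`, 68000 nM
compound 2, `CCOC(=O)c1c(C)oc2ncnc(Nc3cccc(Br)c3)c12`, a limit of the assay, > 1000000 nM
compound 3, `Cc1oc2ncnc(Nc3cccc(Cl)c3)c2c1C(=O)O`, 57500 nM

Compound 1 and compound 3 share one core and differ only by chloro in place of bromo on an aromatic carbon. Their values sit within the scatter of this assay, a 1.2-fold lower number from compound 1 to compound 3 (0.07 log units; within the scatter), so no order between them is read.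

Compound 2 is compound 1 with ethyl in place of hydrogen on an oxygen next to a carbonyl group. This change gave an at least 14-fold higher number from compound 1 to compound 2 (1.16 log units; beyond the scatter). Since compound 2 reports only the limit (the limit of > 1000000 nM in this assay, at which 1 of the 3 values shown sits), the true size of that step is not known; only its lower bound is.

Compound 4, `CCOC(=O)c1c(C)oc2ncnc(Nc3cccc(Cl)c3)c12`, is not yet measured. For the measured compounds named here, it is compound 3 with ethyl in place of hydrogen on an oxygen next to a carbonyl group, the same change as the one from compound 1 to compound 2, at the same place on the same kind of core; the two cores differ only by chloro in place of bromo on an aromatic carbon, a difference that left the value of compound 3 within the scatter of compound 1.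

For compound 4 the expected step in this assay is therefore a 17-fold higher number from compound 3 to compound 4 (1.24 log units; beyond the scatter). This expectation for compound 4 rests on an at least 14-fold higher number from compound 1 to compound 2 (1.16 log units; beyond the scatter) and on the closeness of compound 1 and compound 3 shown by a 1.2-fold lower number from compound 1 to compound 3 (0.07 log units; within the scatter). Compound 4 is accordingly estimated at 1000000 nM, with a range from 250000 nM to 3000000 nM, and it is likely that the assay returns only a limit for compound 4, as it did for compound 2.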

Compound 4, half-maximal inhibitory concentration: > 1000000 nM
Compound 4: no number, only a limit; the forecaster's own chance of this, stated with the estimate: 70%; the middle value sits exactly at the limit.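

In this assay, carboxy to ethoxycarbonyl on the chloro compound gave an at least 17-fold higher number from compound 3 to compound 4 (1.24 log units; beyond the scatter), so on both the bromo and the chloro core the same change moved the number upward by a step beyond the scatter: the same change on two cores in this assay, an at least 14-fold higher number (1.16 log units; beyond the scatter) from compound 1 to compound 2 and an at least 17-fold higher number (1.24 log units; beyond the scatter) from compound 3 to compound 4; the limit leaves it open whether they differ Compound 4 gives > 1000000 nM, which is a limit of the assay and not a number, and that limit caps what can be read for this change in the series: the limit of > 1000000 nM in this assay, at which 2 of the 4 values shown sit. The two pairs show that the direction of the change carries from the bromo core to the chloro core, but they do not show that its size is the same on both, or how far it carries beyond these two cores, and the step between compound 2 and compound 4 cannot be read, as both compounds stand at the limit.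

The compounds shown leave open whether any group in that place gives a readable value between the carboxy compounds and the limit, for instance methoxycarbonyl, a carboxamide or a carboxylic acid on a longer chain. Also open, as far as these compounds go, is whether the closeness of compound 1 and compound 3 holds for other groups on that aromatic carbon, such as fluoro or methoxy.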